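A few compounds are considered here, and "the series" means these few. Any claim that something is new, unique, unknown or untested is made for them only; others in the source may bear on it.

Three compounds sharing one core have numbers in a functional assay on L1210 cells (Mus musculus) for inhibition, read by MTT assay, with a stated time of 72 h; a higher number here means a weaker inhibitor, a lower number a stronger inhibitor. Compound 1 `COc1cc(NC(C)CCCNC(=O)NNC(=O)Nc2ccc(C(F)(F)F)cc2)c2ncccc2c1` gives 18000 nM, compound 2 `COc1cc(NC(C)CCCNC(=O)Nc2ccc(F)cc2)c2ncccc2c1` gives 18000 nM, and compound 3 `COc1cc(NC(C)CCCNC(=O)Nc2cccc(C(F)(F)F)c2)c2ncccc2c1` gives 9200 nM. Compound 3 therefore lies within the usual scatter of both others, so these three numbers cannot be ranked. Among the compounds with values here, the one measured step, a 2.0-fold lower number from compound 2 to compound 3 (0.29 log units; within the scatter), exchanges one substituted phenyl group for another and stays inside that scatter.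

Compound 4 `COc1cc(NC(C)CCCNC(=O)NNC(=O)Nc2cccc(Cl)c2)c2ncccc2c1` has not yet been measured. It keeps the shared core, but ((3-chlorophenyl)carbamoyl)amino stands in place of 3-(trifluoromethyl)phenyl on an amide-type nitrogen (((3-chlorophenyl)carbamoyl)amino in place of 3-(trifluoromethyl)phenyl on an amide-type nitrogen). Within the data shown here, no measured step covers this exact change, so the evidence is indirect. Compound 1 also carries a carbamoylamino group with a substituted phenyl ring at that place, and its 18000 nM sits within the scatter of the number for compound 3. Together with the small step from compound 2, this gives no reason to expect a change beyond the scatter in this assay, in either direction. The expected step is small, a 1.5-fold higher number from compound 3 to compound 4 (0.18 log units; within the scatter). Compound 4 is estimated at 14000 nM, with an expected range from 6000 nM to 32000 nM.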

Compound 4, half-maximal inhibitory concentration: 27000 nM
Beside the measured number, compound 4's estimate is 1.9-fold (0.29 log units) below it, and the stated range covers the measured number.
By their numbers in this assay, from the lowest: compounds 3, 1, 2 and 4 (each within the scatter of the next, the first and the last beyond it).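

In this assay, within the data shown here, the exchange of 3-(trifluoromethyl)phenyl for ((3-chlorophenyl)carbamoyl)amino on the amide-type nitrogen gives a 2.9-fold higher number from compound 3 to compound 4 (0.47 log units; beyond the scatter) and is the first step here to pass beyond the scatter, though only modestly. The other two steps do not support a wider trend: one is a 1.5-fold higher number from compound 2 to compound 4 (0.18 log units; within the scatter) and the other, which keeps the carbamoylamino group and exchanges only 4-(trifluoromethyl)phenyl for 3-chlorophenyl, is a 1.5-fold higher number from compound 1 to compound 4 (0.18 log units; within the scatter), so both remain within the scatter and compound 4 cannot be ranked against compound 1 or compound 2. Nothing measured here explains the step from compound 3 to compound 4.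

The step from compound 3 to compound 4 changes both the carbamoylamino group and the substituent on the phenyl ring, so these compounds cannot show which of the two matters more. As far as these compounds go, it also remains open whether a phenyl ring carrying an amine or a carboxylic acid at this place would move the number beyond the scatter in either direction.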